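The source may hold more compounds than are shown below. What is called first, only, known or untested is meant among the compounds shown, and "the series" means these compounds.

Measured compounds in a functional assay on CCRF-CEM cells (Homo sapiens) for cytotoxicity, read by MTT assay, with a stated time of 72 h; a higher number here means a weaker inhibitor of growth, a lower number a stronger inhibitor of growth:
compound 1, `N#C[Se]c1ccc(NC(=O)OCc2ccc([N+](=O)[O-])cc2)cc1`, gives 9300 nM
compound 2, `N#C[Se]c1ccc(NC(=O)OCc2ccccc2)cc1`, gives 23200 nM
compound 3, `N#C[Se]c1ccc(NC(=O)Oc2ccc(Cl)cc2)cc1`, gives 18300 nM

Among these three, compound 2 carries the highest number; compound 3 lies nearest to it, within the scatter, and compound 1 lies furthest, with a gap beyond the scatter. Within the data shown here, the only step that is measured between compounds differing in one place is a 2.5-fold higher number from compound 1 to compound 2 (0.40 log units; beyond the scatter), and it concerns hydrogen in place of nitro on an aromatic carbon, not the part of the molecule that changes next.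

Compound 4, `CCCCOC(=O)Nc1ccc([Se]C#N)cc1`, differs from compound 2 as follows: propyl in place of phenyl on a saturated chain carbon bound to an oxygen next to a carbonyl group. Among the measured compounds shown here, no measured step bears on this change. Compound 2 and compound 3, which differ in what hangs from the carbamate oxygen, give numbers within the scatter of each other, which is the only hint at how this region behaves. The expectation for this assay is therefore a step of no clear direction, not beyond the scatter, with wide uncertainty. Compound 4 is estimated at 25000 nM, within a range of 10000 nM to 60000 nM. This estimate means a step of a 1.1-fold higher number from compound 2 to compound 4 (0.03 log units; within the scatter), expected to stay within the usual scatter.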

Compound 4, concentration for 50% growth inhibition: 6500 nM
For compound 4 the middle estimate is 3.8-fold (0.59 log units) above the measured one; the measured number lies below the stated range.
By their numbers in this assay, from the lowest: compounds 4, 1, 3 and 2 (each within the scatter of the next, the first and the last beyond it).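

In this assay, among these compounds, putting propyl in place of phenyl on a saturated chain carbon bound to an oxygen next to a carbonyl group gives a 3.6-fold lower number from compound 2 to compound 4 (0.55 log units; beyond the scatter), which shows that the number responds to what this position carries, a point the only earlier step, hydrogen in place of nitro on an aromatic carbon, could not address. The six-membered aromatic ring of phenyl is also not needed here for growth inhibition, since compound 4, whose entering propyl has no ring, gives 6500 nM. No measurement shown here accounts for this step, and its cause remains unknown.

The single step changes the aromatic ring and the carbon count together, so the compounds shown cannot separate the two, and a cyclohexyl group at this place would be needed to tell them apart. They also leave open how far the trend extends along a chain, for instance whether a longer chain such as hexyl, or a chain ending in an amine or a carboxylic acid, would move the number further in this assay.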